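Dropping the Hydroxy Next to the Hydrazone Linker

This account rests on a few compounds, and the source may have more. Where it says the series, first, only, none or still open, it means among the compounds named here.

Three compounds share one core and are compared in a functional assay on K562 cells (Homo sapiens) for antiproliferative activity, read by cell counting, with a stated time of 7 days; a lower number here means a stronger inhibitor, a higher number a weaker inhibitor. Compound 1 `O=C(N/N=C/c1cc(Cl)ccc1O)c1cc2ccccc2o1` gives 3700 nM, compound 2 `O=C(N/N=C/c1ccc(O)cc1)c1cc2ccccc2o1` gives 79900 nM, and compound 3 `O=C(N/N=C/c1cc(O)ccc1O)c1cc2ccccc2o1` gives 36800 nM. Compound 3 thus stands second highest of the three numbers, nearest to compound 2 and furthest from compound 1.

For the measured compounds named here, the only single-point step measured is a 9.9-fold higher number from compound 1 to compound 3 (1.00 log units; beyond the scatter), which is a change on the same ring but of a different kind. Compound 4 `O=C(N/N=C/c1cccc(O)c1)c1cc2ccccc2o1` is made from compound 3 by hydrogen in place of hydroxy on an aromatic carbon. Going by the values given here, no measured step covers removal of a hydroxy, so the expectation is weak. Compound 2, which also carries a single hydroxy, sits above compound 3, and a similar drift toward a higher number is expected here, so the step from compound 3 to compound 4 is estimated as a 1.6-fold higher number from compound 3 to compound 4 (0.21 log units; within the scatter). Compound 4 is therefore expected to give about 60000 nM in this assay, within a range of 20000 nM to 180000 nM.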

Compound 4, half-maximal inhibitory concentration: 52400 nM
Estimate against measurement, compound 4: 1.1-fold (0.06 log units) above, and the stated range covers the measured number.
By their numbers in this assay, from the lowest: compound 1; then compounds 3, 4 and 2 (each within the scatter of the next, the first and the last beyond it).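

In this assay replacing the hydroxy ortho to a large group with hydrogen gives a 1.4-fold higher number from compound 3 to compound 4 (0.15 log units; within the scatter) and so, unlike the chloro-to-hydroxy change, this change cannot be told apart from the scatter. Compound 4 also shows that 3-hydroxyphenyl in place of 4-hydroxyphenyl gives a 1.5-fold lower number from compound 2 to compound 4 (0.18 log units; within the scatter) and so, for these two compounds with a single hydroxy, the place of that hydroxy makes no clear difference in this measurement. No evidence is at hand on what lies behind these numbers.

The compounds shown leave open how an amine or a methoxy group at this position would read in this assay. They also leave open whether the chloro would keep the value of compound 1 at 3700 nM without the hydroxy ortho to a large group.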